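Swapping Sulfanyl for Bromo on a Shared Core

The source may report more compounds than this note shows. Statements on the series, on what has been measured and on what is new or still open speak of the compounds shown alone.

Compound 3 `OCC(CO)OCn1c(S)nc2c(Cl)cc(Cl)cc21` has been tested in a functional assay on KB cells (Homo sapiens) for inhibition (a lower number here means a stronger inhibitor, a higher number a weaker inhibitor), and gives > 100000 nM, which is a limit of the assay rather than a number. Compound 1 `CN(C)c1nc2c(Cl)cc(Cl)cc2n1COC(CO)CO` also reaches only the limit > 100000 nM in this assay. Compound 2 `OCC(CO)OCn1c(S)nc2cc(Cl)c(Cl)cc21` likewise gives the limit > 100000 nM. Because all three values sit at the limit of > 100000 nM in this assay, at which 3 of the 3 values shown sit, the step that the two limits leave unreadable from compound 1 to compound 3 cannot be read. Compound 4 `OCC(CO)OCn1c(Br)nc2c(Cl)cc(Cl)cc21` differs from compound 3 by bromo in place of sulfanyl on an aromatic carbon. Going by the values given here, no measured step involves a bromo group, and the one nearby step is unreadable, so the expectation for compound 4 rests only on compound 3, whose value > 100000 nM is a limit. Compound 4 is therefore expected to remain near that limit, the expected step of a number no higher from compound 3 to compound 4 (the limit leaves the size open) being small. The estimated value for compound 4 is 100000 nM, with a range from 20000 nM to 300000 nM.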

Compound 4, half-maximal inhibitory concentration: > 100000 nM
Compound 4 gave a limit, no number; the forecaster's own chance of this, stated with the estimate: 75%; the middle value sits exactly at the limit.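

Compound 4 gives only a limit, as do compound 1 and compound 3, so no step among them can be read: the limit of > 100000 nM in this assay, at which 4 of the 4 values shown sit.

The compounds shown leave open whether dimethylamino, sulfanyl or bromo on the shared core makes any difference in this assay.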